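Benzyl ester on the furan-3-yl thiourea core

The source may hold more compounds than are shown below. What is called first, only, known or untested is meant among the compounds shown, and "the series" means these compounds.

Two compounds of the series have numbers. Compound 1 `CC1=C(C(=O)OCc2ccccc2)C(c2ccco2)NC(=S)N1` in an assay on membranes from HEK293 cells for displacement of a labelled ligand from adenosine receptor A2b (Homo sapiens), read by scintillation counting, with a stated time of 30 min, tested at 1 uM (on this read-out higher numbers stand for more inhibition at the one concentration tested (going by the name of the read-out) and lower numbers for less inhibition), gives 41%. Compound 2 `CC1=C(C(=O)OCC(C)C)C(c2ccoc2)NC(=S)N1` in this assay gives 1%, the lowest of the two numbers, and its nearest neighbour compound 1 stands higher by an amount beyond the scatter. Within the data shown here, no pair of measured compounds differs in a single place, so no step has been measured. Compound 3 `CC1=C(C(=O)OCc2ccccc2)C(c2ccoc2)NC(=S)N1` is next in line for this assay. It is compound 2 with phenyl in place of isopropyl on a saturated chain carbon bound to an oxygen next to a carbonyl group; compound 3 therefore carries the same ester as compound 1 while keeping the rest of compound 2.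

From compound 2 to compound 3 an upward step is expected, a number 24 percentage points higher from compound 2 to compound 3 (beyond the scatter), a rough guess anchored between the numbers of compound 2 and compound 1. For compound 3 the expected inhibition is 25%, within a range of 5% to 50%.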

Compound 3, a percentage reported as inhibition, at one concentration (the size of the read-out at that concentration, not a potency): 36%
For compound 3 the middle estimate is 11 percentage points below the measured one, and the stated range covers the measured number.
By their numbers in this assay, from the lowest: compound 2; then compounds 3 and 1 (each within the scatter of the next).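

In this assay, phenyl in place of isopropyl on a saturated chain carbon bound to an oxygen next to a carbonyl group gives a number 35 percentage points higher from compound 2 to compound 3 (beyond the scatter) on an otherwise unchanged compound, so this position now has a measured step, which the earlier pair, differing in two places, could not provide. Furan-3-yl in place of furan-2-yl on a saturated ring carbon gives a number 5 percentage points lower from compound 1 to compound 3 (within the scatter), so with the benzyl ester this read-out does not separate the two furans. Nothing measured here accounts for either step.

Going by these compounds, whether isobutyl to benzyl gives a similar step with furan-2-yl remains open. Also open, on these data alone, is how a longer chain such as phenethyl, or a chlorine on the benzyl ring, would read in this assay at this position.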